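The source may report more compounds than this note shows. Statements on the series, on what has been measured and on what is new or still open speak of the compounds shown alone.

In an ADME assay on MRC5 cells (Homo sapiens), read by MTT assay, with a stated time of 72 h (a lower number here means a stronger inhibitor, a higher number a weaker inhibitor), compound 2 `C#Cc1cn([C@@H]2O[C@H](CO)[C@@H](O)[C@H]2O)c2ncnc(C)c12` gives 1440 nM. Compound 1 `Cc1ncnc2c1c(I)cn2[C@@H]1O[C@H](CO)[C@@H](O)[C@H]1O` differs from compound 2 by one change, (iodo in place of ethynyl on an aromatic carbon), and in this assay compound 1 gives 13300 nM. The step of a 9.2-fold higher number from compound 2 to compound 1 (0.97 log units; beyond the scatter) shows that this change weakened the compound.

Compound 3 `C#Cc1cn([C@@H]2O[C@H](CO)[C@@H](O)[C@H]2O)c2ncnc(OC)c12` differs from compound 2 at a different place; the two cores differ by methoxy in place of methyl on an aromatic carbon. For compound 3 the read-out in this assay is only a limit, > 100000 nM. That value sits at the limit of > 100000 nM in this assay, at which 1 of the 3 values shown sits, so the step of an at least 69-fold higher number from compound 2 to compound 3 (1.84 log units; beyond the scatter) is known only as a lower bound on its size.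

Compound 4 `COc1ncnc2c1c(I)cn2[C@@H]1O[C@H](CO)[C@@H](O)[C@H]1O` has not yet been measured. It stands to compound 3 as compound 1 stands to compound 2: the change is iodo in place of ethynyl on an aromatic carbon, and the surroundings of the place are described in the same words for both pairs, so it is the same change made on the core of compound 3 rather than on the core of compound 2.

Since compound 3 already reaches only a limit, compound 4 is expected to do no better, and it is likely that this assay again reports only a limit for compound 4. The expected step for compound 4 is a step that the limit leaves unreadable from compound 3 to compound 4, resting on the measured step of the same change, a 9.2-fold higher number from compound 2 to compound 1 (0.97 log units; beyond the scatter). Compound 4 is thus estimated to give 400000 nM in this assay.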

Compound 4, half-maximal inhibitory concentration: 63000 nM
For compound 4 the middle estimate is 6.3-fold (0.80 log units) above the measured one, and the stated range ends above it.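

In this assay, iodo in place of ethynyl does not carry over from one core to the other: on the core of compound 3 it gives an at least 1.5-fold lower number from compound 3 to compound 4 (0.20 log units; that floor lies within the scatter) and so does not repeat the clear rise in number seen on the core of compound 2, and the two steps differ: the same change on two cores in this assay, a 9.2-fold higher number (0.97 log units; beyond the scatter) from compound 2 to compound 1 and an at least 1.5-fold lower number (0.20 log units; that floor lies within the scatter) from compound 3 to compound 4, at least 14-fold (1.16 log units) apart, beyond the scatter of two such steps. Methoxy in place of methyl also gives a 4.7-fold higher number from compound 1 to compound 4 (0.68 log units; beyond the scatter) on the iodo core, which points the same way as on the ethynyl core, yet the size of the step still depends on the core: the same change on two cores in this assay, an at least 69-fold higher number (1.84 log units; beyond the scatter) from compound 2 to compound 3 and a 4.7-fold higher number (0.68 log units; beyond the scatter) from compound 1 to compound 4, at least 14-fold (1.16 log units) apart, beyond the scatter of two such steps. For compound 3, > 100000 nM is a limit of the assay and not a number, so these four compounds show that neither change can simply be copied across cores, but they do not show the true size of the gap between the steps or why it arises.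

The compounds shown leave open how a nitrile or a longer chain in place of ethynyl or iodo, or an amine in place of methyl or methoxy, would behave on the shared core. They also leave open whether the same mismatch would appear on a third core.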